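A few compounds are considered here, and "the series" means these few. Any claim that something is new, unique, unknown or untested is made for them only; others in the source may bear on it.

For the measured compounds named here, in a functional assay on PC-3 cells (Homo sapiens) for inhibition, read by MTT assay (on this read-out higher numbers stand for weaker inhibition and lower numbers for stronger inhibition), two compounds have numbers so far. Compound 1 `O=C(CCCCCCC(=O)Nc1nnc(-c2ccco2)s1)NO` stands lowest at 880 nM, while compound 2 `O=C(CCC(=O)Nc1nnc(-c2ccc(O)cc2)s1)NO` gives 14700 nM, a gap beyond the usual scatter. These two compounds differ in more than one place, so their gap says nothing about any single group.

Compound 3 `Cc1ccc(-c2nnc(NC(=O)CCCCCCC(=O)NO)s2)s1` keeps the rest of compound 1 and alters one group: 5-methylthiophen-2-yl in place of furan-2-yl on an aromatic carbon, with 5-methylthiophen-2-yl in place of furan-2-yl on an aromatic carbon. Going by the values given here, no measured pair shows a swap of this kind, so the data give no direct guide to its size or direction. The expected outcome in this assay is therefore no change beyond the scatter, and the estimated step, a 1.1-fold higher number from compound 1 to compound 3 (0.06 log units; within the scatter), is small. For compound 3 the expected value is 1000 nM, with an estimated range from 350 nM to 3000 nM.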

Compound 3, half-maximal inhibitory concentration: 880 nM
Beside the measured number, compound 3's estimate is 1.1-fold (0.06 log units) above it; measured number inside the range.
By their numbers in this assay, from the lowest: compounds 1 and 3 (each within the scatter of the next); then compound 2.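

In this assay, replacing furan-2-yl with 5-methylthiophen-2-yl gives no change at the digits printed from compound 1 to compound 3 (within the scatter). For the compounds shown here, this is the first single-place comparison, since compounds 1 and 2 differ in more than one place. It shows that this aromatic carbon of the core of compound 1 can carry a five-membered aromatic ring with sulfur and one more heavy atom, with no change in the number beyond the scatter. Nothing on hand explains this outcome.

Because the ring hetero atom and the methyl group change together, the pair cannot separate their individual contributions, and a gain from one could be offset by a loss from the other. It also leaves open whether a group of a different kind at this place, such as an amine or a carboxylic acid, would hold the number.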